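Changing the Amide Cap: Trifluoromethyl to Propyl

A few compounds are considered here, and "the series" means these few. Any claim that something is new, unique, unknown or untested is made for them only; others in the source may bear on it.

Compound 1, `COc1ccc(C(=O)Nc2cccc(-c3oc4cc(-c5ccc(F)cc5)ccc4c(=O)c3O)c2)cc1`: 5490 nM
Compound 2, `O=C(Nc1cccc(-c2oc3cc(-c4ccc(F)cc4)ccc3c(=O)c2O)c1)c1ccc(C(F)(F)F)cc1`: 7350 nM
Compound 3, `Cc1cc(C)cc(C(=O)Nc2cccc(-c3oc4cc(-c5ccc(F)cc5)ccc4c(=O)c3O)c2)c1`: 4860 nM

Three compounds share one core and differ only in the aromatic ring of the amide cap. All were tested in a functional assay on HCC1937 cells (Homo sapiens) for antiproliferative activity, read by CCK-8 assay, with a stated time of 72 h; on this read-out lower numbers stand for stronger inhibition and higher numbers for weaker inhibition. Compound 2 gives the highest of the three numbers, yet its steps to the other two are both within the scatter: a 1.3-fold higher number from compound 1 to compound 2 (0.13 log units; within the scatter) and a 1.5-fold lower number from compound 2 to compound 3 (0.18 log units; within the scatter). The remaining step, a 1.1-fold lower number from compound 1 to compound 3 (0.05 log units; within the scatter), is within the scatter as well. Across these three, then, changing the group on the amide cap has produced no measurable difference in this assay.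

Compound 4, `CCCc1ccc(C(=O)Nc2cccc(-c3oc4cc(-c5ccc(F)cc5)ccc4c(=O)c3O)c2)cc1`, has not yet been measured. Compared with compound 2 the change is this: propyl in place of trifluoromethyl on an aromatic carbon. The two measured steps that start from compound 2 bear on it, since each also exchanged the group on that same aromatic ring, and neither moved the number beyond the scatter. Within the data shown here, no measured step involves propyl, so the expectation rests only on that observed indifference. Compound 4 is therefore expected to give an estimate of 5500 nM in this assay, with a range from 2500 nM to 12000 nM. This estimate means a step of a 1.3-fold lower number from compound 2 to compound 4 (0.13 log units; within the scatter), which is expected to remain within the scatter.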

Compound 4, half-maximal inhibitory concentration: 15400 nM
Estimate against measurement, compound 4: 2.8-fold (0.45 log units) below; measured number above the stated range.
By their numbers in this assay, from the lowest: compounds 3, 1 and 2 (each within the scatter of the next); then compound 4.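

Propyl is the first group on this aromatic ring of the amide cap to move the number beyond the scatter in this assay, with modest steps against all three earlier compounds (a 2.1-fold higher number from compound 2 to compound 4 (0.32 log units; beyond the scatter)) (a 2.8-fold higher number from compound 1 to compound 4 (0.45 log units; beyond the scatter)) (a 3.2-fold higher number from compound 3 to compound 4 (0.50 log units; beyond the scatter)). The earlier compounds shown here suggested that this ring would accept any change without a measurable effect, but that holds only for the methoxy, trifluoromethyl and 3,5-dimethylphenyl caps, which remain within the scatter of one another, while the 4-propylphenyl cap of compound 4 stands apart with weaker inhibition. The data shown offer no measurement that accounts for this difference.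

A single propyl compound cannot show whether the weaker inhibition follows the length of the chain, which an ethyl or butyl group in the same place would test, or is particular to propyl. As far as these compounds go, how a different kind of group, such as an amine or a carboxylic acid, would read on this ring also remains open.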